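A few compounds are considered here, and "the series" means these few. Any claim that something is new, unique, unknown or untested is made for them only; others in the source may bear on it.

Working notes on the series. Four compounds share one core, which carries a hydroxyl, a methyl and two enone arms on the central ring; they differ in the aryl group and in the arm ends. Compound 1 `Cc1cc(O)c(C(=O)/C=C/c2ccccc2)c(-c2ccc(Cl)cc2)c1C(=O)/C=C/c1ccccc1` carries a 4-chlorophenyl group and phenyl-ended arms; in a functional assay on MDA-MB-231 cells (Homo sapiens) for cytotoxicity, read by MTT assay, with a stated time of 24 h (a higher number here means a weaker inhibitor, a lower number a stronger inhibitor), compound 1 gives 4400 nM. Compound 2 `Cc1cc(O)c(C(=O)/C=C/c2ccccc2)c(-c2ccccc2)c1C(=O)/C=C/c1ccccc1` has phenyl in place of 4-chlorophenyl; in this assay compound 2 gives 8500 nM. Going by the values given here, the single change between the two, (chloro in place of hydrogen on an aromatic carbon), gave a 1.9-fold lower number from compound 2 to compound 1 (0.29 log units; within the scatter), so the two values cannot be told apart.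

Compound 3 `Cc1cc(O)c(C(=O)/C=C/c2cccc3ccccc23)c(-c2ccccc2)c1C(=O)/C=C/c1cccc2ccccc12` keeps the phenyl group of compound 2 but carries larger arm ends; the difference between the two cores is not broken down here. In this assay compound 3 is reported as "not active" (no number reported), with no single number.

Compound 4 `Cc1cc(O)c(C(=O)/C=C/c2cccc3ccccc23)c(-c2ccc(Cl)cc2)c1C(=O)/C=C/c1cccc2ccccc12` is not yet measured. It differs from compound 3 by chloro in place of hydrogen on an aromatic carbon, the same change, at the same place, as from compound 2 to compound 1. On the core of compound 2 that change gave only a 1.9-fold lower number from compound 2 to compound 1 (0.29 log units; within the scatter), and compound 3 itself shows no single number, so little movement is expected from the chloro alone. Compound 4 is expected in this assay near 40000 nM, estimated between 10000 nM and 150000 nM, with a substantial chance that no number is reported.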

Compound 4, half-maximal inhibitory concentration: 30000 nM
For compound 4 the middle estimate is 1.3-fold (0.12 log units) above the measured one; the range from low to high includes it.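

In this assay compound 4 gives 30000 nM while compound 3 has no single number, so no new step can be read between compound 3 and compound 4. No evidence bearing on this result is available. The compounds shown leave open what chloro in place of hydrogen does on the core of compound 3, where one end of that change has no number.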